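Swapping Carbamoylmethyl for a Methyl Oxadiazole on a Shared Core

The source may hold more compounds than are shown below. What is called first, only, known or untested is meant among the compounds shown, and "the series" means these compounds.

Of the compounds shown here, two built on one core have been measured in a functional assay (Saphenous vein) for binding affinity, with Oryctolagus cuniculus as the target; on this read-out lower numbers stand for tighter binding and higher numbers for weaker binding. Compound 1 `CN(C)[C@H]1C[C@H](c2c[nH]c3ccc(CC(N)=O)cc32)C1` gives 16600 nM, the higher of the two numbers. Compound 2 `CN(C)[C@H]1C[C@H](c2c[nH]c3ccc(CN4C(=O)NC(C)(C)C4=O)cc32)C1` gives 589 nM, and the gap between the two lies well beyond the usual scatter. Compound 1 therefore stands at the weak end of this very small set.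

Compound 3 `Cc1noc(-c2ccc3[nH]cc([C@H]4C[C@H](N(C)C)C4)c3c2)n1` has not yet been measured. It keeps the core of compound 1 but carries 3-methyl-1,2,4-oxadiazol-5-yl in place of carbamoylmethyl on an aromatic carbon. Among the compounds with values here, no measured pair of compounds differs in one place only, so this swap has no direct precedent. Within the data shown here, the only guide is compound 2 at 589 nM, which shows that a much lower number is reachable on this core. Tighter binding is therefore expected in this assay, with an expected step of a 21-fold lower number from compound 1 to compound 3 (1.32 log units; beyond the scatter), though this expectation is loosely founded. Compound 3 is estimated at 800 nM, with an expected range from 150 nM to 4000 nM.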

Compound 3, dissociation constant: 955 nM
Estimate against measurement, compound 3: 1.2-fold (0.08 log units) below; the range from low to high includes it.
By their numbers in this assay, from the lowest: compounds 2 and 3 (each within the scatter of the next); then compound 1.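

In this assay, within the data shown here, putting 3-methyl-1,2,4-oxadiazol-5-yl in place of carbamoylmethyl on this aromatic carbon gives the first change in the set that can be read at a single place: a 17-fold lower number from compound 1 to compound 3 (1.24 log units; beyond the scatter), a large step. The number therefore depends strongly on what this aromatic carbon carries, and a second, quite different group now reaches the level of the first: compound 2 gives 589 nM and compound 3 gives 955 nM, values within the scatter of each other. Nothing available bears on why the swap has this effect.

With only these groups at this position, the step cannot be divided between the arrival of the five-membered aromatic ring with 3 hetero atoms and the departure of carbamoylmethyl, which carries 1 hydrogen-bond donor where the new group has 0 hydrogen-bond donors. From the compounds shown here alone, whether the methyl on the ring contributes also stays open, and so does how an N,N-dimethylcarbamoylmethyl group or a methyl ester would read at this position in this assay.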